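The compounds below may be only part of what the source reports. "The series", "measured", "known", "first", "only" and "open" are said of these compounds alone.

Measured in a functional assay on the whole organism (strain Swiss albino) for inhibition, with Mus musculus as the target, in the writhing test, with stated times of 60 min and 15 min, at a dose of 100 mg/kg by the oral route; on this read-out higher numbers stand for more inhibition at the one dose given (going by the name of the read-out) and lower numbers for less inhibition:
compound 1 `CCN(CC)C(=O)CC1CCc2cc(OC)c(OC)cc21` — 27.4%
compound 2 `COc1cc2c(cc1OC)C(CC(=O)NC(C)(C)C)CC2` — 41.8%
compound 3 `CCCCCCNC(=O)CC1CCc2cc(OC)c(OC)cc21` — 82.2%

Compound 3 stands highest of the three, with a number 40.4 percentage points higher from compound 2 to compound 3 (beyond the scatter) and a number 54.8 percentage points higher from compound 1 to compound 3 (beyond the scatter), both beyond the scatter. Compound 4 `COc1cc2c(cc1OC)C(CC(=O)N1CCCCC1)CC2` differs from it by piperidin-1-yl in place of hexylamino on a carbonyl carbon. The step bearing most on this is a number 54.8 percentage points higher from compound 1 to compound 3 (beyond the scatter), where the amide nitrogen carried two alkyl groups as it will in compound 4; a number 14.4 percentage points higher from compound 1 to compound 2 (beyond the scatter) points the same way, the doubly substituted nitrogen being the lower of the pair. Compound 4 is therefore expected to sit well below compound 3 in this assay, with an estimated a number 49.2 percentage points lower from compound 3 to compound 4 (beyond the scatter). The estimate for compound 4 is 33%, in the range 15% to 55%.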

Compound 4, a percentage reported as inhibition, in the whole organism at one dose (the size of the read-out at that dose, not a potency): 44.7%
Compound 4: middle estimate off by 11.7 percentage points, on the low side; measured number inside the range.
By their numbers in this assay, from the lowest: compound 1; then compounds 2 and 4 (each within the scatter of the next); then compound 3.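

In this assay, piperidin-1-yl in place of hexylamino on the carbonyl carbon gives a number 37.5 percentage points lower from compound 3 to compound 4 (beyond the scatter), so the high number does not survive this change. Keeping the amide hydrogen does not alone set the number, as (tert-butyl)amino, which has that hydrogen, and piperidin-1-yl, which lacks it, give a number 2.9 percentage points higher from compound 2 to compound 4 (within the scatter), while two groups without it, diethylamino and piperidin-1-yl, give a number 17.3 percentage points higher from compound 1 to compound 4 (beyond the scatter). Nothing available explains these differences. Open, as far as these compounds go, is how the number runs with butylamino or octylamino on this carbonyl carbon, and so whether the high number is particular to hexylamino.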